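The source may report more compounds than this note shows. Statements on the series, on what has been measured and on what is new or still open speak of the compounds shown alone.

Compound 1 `COc1ccc(OC)c(N2C(=O)CSC2c2cccc(C(=O)NCCCCc3ccccc3)c2)c1` gives > 1000 nM in a functional assay on HOS-TE85 cells (Homo sapiens) for inhibition, read by CCK-8 assay, with a stated time of 72 h (on this read-out higher numbers stand for weaker inhibition and lower numbers for stronger inhibition), which is a limit of the assay and not a number.
Compound 2 `O=C(NCCCCc1ccccc1)c1cccc(C2SCC(=O)N2c2ccc(-c3ccccc3)cc2)c1` gives > 1000 nM in this assay, again a limit and not a number.
Compound 3 `O=C(NCCCCc1ccccc1)c1cccc(C2SCC(=O)N2c2ccccn2)c1` gives 19.7 nM in this assay.

Within the data shown here, compound 3 therefore holds the only number among the three results; the other two compounds sit at the limit of > 1000 nM in this assay, at which 2 of the 3 values shown sit. The step to compound 4 `O=C(NCCCCc1ccccc1)c1cccc(C2SCC(=O)N2c2nccs2)c1` changes the group on the amide-type nitrogen of the shared core: 1,3-thiazol-2-yl in place of pyridin-2-yl on an amide-type nitrogen in a ring.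

Among the measured compounds shown here, two measured steps bear on this position. There is an at least 50-fold lower number from compound 1 to compound 3 (1.70 log units; beyond the scatter) and an at least 50-fold lower number from compound 2 to compound 3 (1.70 log units; beyond the scatter), both large and both beyond the scatter, so the group on this nitrogen clearly matters in this assay. Neither step, however, involves a 1,3-thiazol-2-yl, so the size of the new step cannot be read from them; the swap from one six-membered aromatic ring with 1 hetero atom to one five-membered aromatic ring with 2 hetero atoms is a closer change than either of those measured ones.

The expectation is that compound 4 stays near compound 3, with at most a modest step, estimated as a 2.0-fold higher number from compound 3 to compound 4 (0.31 log units; beyond the scatter). The estimate for compound 4 in this assay is 40 nM, with a range from 10 nM to 250 nM.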

Compound 4, half-maximal inhibitory concentration: > 1000 nM
Compound 4 gave a limit, no number (the forecaster's own chance of this, stated with the estimate: 10%); middle value at least 25-fold (1.39 log units) away from the limit.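

In this assay, replacing pyridin-2-yl with 1,3-thiazol-2-yl on the amide-type nitrogen gives an at least 50-fold higher number from compound 3 to compound 4 (1.70 log units; beyond the scatter), so even a change from one small aromatic ring with hetero atoms to another does not preserve the result at this position. The earlier compounds had shown only that the 2,5-dimethoxyphenyl of compound 1 and the 4-phenylphenyl of compound 2 gave limits rather than numbers, whereas compound 4 adds a five-membered aromatic ring with 2 hetero atoms to that group. Pyridin-2-yl is therefore the only group of the four on this nitrogen that gives a number, and the other three results share one limit of the assay: the limit of > 1000 nM in this assay, at which 3 of the 4 values shown sit.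

The steps among compound 1, compound 2 and compound 4 cannot be read, as all three results are limits, so these compounds cannot be ranked against one another. Still open, on these data alone, is whether a plain phenyl, a pyrimidin-2-yl or a 1,3-oxazol-2-yl on this nitrogen would give a number in this assay, and so whether anything beyond pyridin-2-yl works here.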